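The compounds below may be only part of what the source reports. "The series", "measured", "known", "first", "only" and "open" are said of these compounds alone.

Measured in an ADME assay on HepG2 2.2.15 cells (Homo sapiens) for cytotoxicity, read by MTT assay, with a stated time of 72 h; a lower number here means that less compound is tolerated, a higher number that more compound is tolerated:

compound 1 `O=C1OCCc2c(CO)cccc21`: > 3800000 nM, a limit
compound 2 `CCOCC(=O)OCc1cccc2c1CCOC2=O`: > 3680000 nM, a limit
compound 3 `O=C1OCCc2c(COC(=O)C3CCCCC3)cccc21`: > 1840000 nM, a limit

Compound 1 has no number of its own and stands only at the limit of > 3800000 nM in this assay, at which 1 of the 3 values shown sits. The other two compounds also stand only at limits, so the three cannot be ranked against one another.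

Compound 4 `O=C(O)c1cccc2c1CCOC2=O` has not yet been measured. It differs from compound 1 as follows: carboxy in place of hydroxymethyl on an aromatic carbon. In words, carboxy takes the place of hydroxymethyl on an aromatic carbon.

For the measured compounds named here, two measured steps bear on this change, and only indirectly. One is a step that the two limits leave unreadable from compound 1 to compound 2, where (ethoxymethyl)carbonyl replaces hydrogen on an oxygen on a saturated carbon. The other is a step that the two limits leave unreadable from compound 2 to compound 3, where cyclohexyl replaces ethoxymethyl on a carbonyl carbon. Neither has a readable size, and neither introduces carboxy.

Nothing measured therefore points to a change in either direction. No step beyond the scatter is expected in this assay, and compound 4 is likely to be reported as a limit as well.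

The estimated value for compound 4 is 3500000 nM, with an expected range from 1200000 nM to 6000000 nM.

This estimate corresponds to an at least 1.0-fold lower number from compound 1 to compound 4 (0.03 log units; that floor lies within the scatter).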

Compound 4, half-maximal cytotoxic concentration: > 4540000 nM
Compound 4: only a limit was reported; the forecaster's own chance of this, stated with the estimate: 85%; middle value at least 1.2-fold (0.11 log units) away from the limit.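

In this assay compound 4 gives > 4540000 nM as a limit. Compound 1 likewise gives > 3800000 nM as a limit. For the compounds shown here, no step from compound 1 to compound 4 can therefore be read. The compounds shown leave open at what concentration any of them becomes cytotoxic, and whether carboxy in place of hydroxymethyl alters that concentration.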